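Bromine on a Distal Phenyl Ring in Two Sulfonamide Series

The source may report more compounds than this note shows. Statements on the series, on what has been measured and on what is new or still open speak of the compounds shown alone.

Compound 1 `NS(=O)(=O)c1ccc(C(=O)N/N=C(/CS(=O)(=O)c2ccccc2)c2ccccc2)cc1` gives 10700 nM in a functional assay on MCF7 cells (Homo sapiens) for antiproliferative activity, read by MTT assay; on this read-out higher numbers stand for weaker inhibition and lower numbers for stronger inhibition. Compound 2 `NS(=O)(=O)c1ccc(C(=O)N/N=C(/CS(=O)(=O)c2ccccc2)c2ccc(Br)cc2)cc1` carries bromo in place of hydrogen on an aromatic carbon, and this change made a 1.8-fold higher number from compound 1 to compound 2 (0.25 log units; within the scatter). In this assay compound 2 gives 19100 nM. Compound 3 `NS(=O)(=O)c1ccc(N/C=C(\C(=O)c2ccccc2)S(=O)(=O)c2ccccc2)cc1` rests on a different core; how that core differs from the core of compound 1 is not broken down here. In this assay compound 3 gives 3440 nM, the lowest of the three numbers, beyond the scatter from both compound 1 and compound 2.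

Compound 4 `NS(=O)(=O)c1ccc(N/C=C(\C(=O)c2ccc(Br)cc2)S(=O)(=O)c2ccccc2)cc1` has not yet been measured. It bears the same kind of change as compound 2, bromo in place of hydrogen on an aromatic carbon, here reading benzoyl to (4-bromophenyl)carbonyl. Because a 1.8-fold higher number from compound 1 to compound 2 (0.25 log units; within the scatter) stayed within the scatter, compound 4 is expected to show a step of about a 1.6-fold higher number from compound 3 to compound 4 (0.20 log units; within the scatter) in this assay. On that basis compound 4 is estimated at 5500 nM, with a likely range from 2500 nM to 13000 nM, resting on a single measured pair.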

Compound 4, half-maximal inhibitory concentration: 62700 nM
For compound 4 the middle estimate is 11-fold (1.06 log units) below the measured one, outside the stated range (above it).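

In this assay, bromo in place of hydrogen on the second core gave an 18-fold higher number from compound 3 to compound 4 (1.26 log units; beyond the scatter), a weakening of inhibition that the earlier step on the core of compound 1 did not foretell. Set side by side, the two steps differ, so this change cannot be carried from one core to the other in this series as a fixed step: the same change on two cores in this assay, a 1.8-fold higher number (0.25 log units; within the scatter) from compound 1 to compound 2 and an 18-fold higher number (1.26 log units; beyond the scatter) from compound 3 to compound 4, 10-fold (1.01 log units) apart, beyond the scatter of two such steps. Within the data shown here, this rests on only two matched pairs, however: it does not show which feature of the two cores goes with the difference, and it sets no rule for any further core.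

The compounds shown carry only hydrogen or bromo at this place on the aromatic ring, so it remains open whether the large step on the second core belongs to bromo itself or would also appear with chloro, methoxy or an amine there. From the compounds shown here alone, it also remains open whether such groups would separate the two cores in the same way.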